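This account rests on a few compounds, and the source may have more. Where it says the series, first, only, none or still open, it means among the compounds named here.

Measured so far:
compound 1, `CN(C)C(=O)CN1CCC(c2cc3c(-c4ccc(=O)n(C)c4)ccnc3[nH]2)CC1`: > 1000000 nM
compound 2, `CC(C)n1cc(-c2ccnc3[nH]c(C4CCN(CC(=O)N5CCCCC5)CC4)cc23)ccc1=O`: 79000 nM

Compound 1 stands at the limit of > 1000000 nM in this assay, at which 1 of the 2 values shown sits; its reading in a physicochemical assay for solubility, in phosphate buffer, at pH 7.4 (on this read-out higher numbers stand for higher solubility and lower numbers for lower solubility), is a limit of the assay, not a number. Compound 2, measured in this assay, gives a number, 79000 nM. Among the compounds with values here, no step between measured compounds that differ in one place is available, so the size of any single change is not fixed by what has been measured.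

Compound 3, `CCn1cc(-c2ccnc3[nH]c(C4CCN(CC(=O)N(C)C)CC4)cc23)ccc1=O`, has not yet been measured. It differs from compound 1 by methyl in place of hydrogen on a saturated chain carbon bound to an aromatic nitrogen. Because compound 1 reports only > 1000000 nM, a downward move of moderate size in compound 3 would still leave it very soluble. The expected step of an at least 1.6-fold lower number from compound 1 to compound 3 (0.22 log units; that floor lies within the scatter) is small and downward, possibly none beyond the scatter. Compound 3 is expected to give about 600000 nM, within a range from 200000 nM to 1500000 nM.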

Compound 3, solubility: > 1000000 nM
Compound 3: no number, only a limit; the forecaster's own chance of this, stated with the estimate: 40%; at least 1.6-fold (0.22 log units) between middle value and limit.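

Compound 1 and compound 3 both give a limit, not a number, in this assay, so no step between them can be read: the limit of > 1000000 nM in this assay, at which 2 of the 3 values shown sit.

The compounds shown leave open whether the change from methyl to ethyl moves this reading at all, and by how much.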